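The compounds below may be only part of what the source reports. "The series", "measured", "known", "first", "only" and "open" are said of these compounds alone.

Compound 1 `Cc1nc(N)sc1CCCN/C(N)=N/C(=O)NCc1ccco1` gives 0.58 in a functional assay on Right cardiac atrium for agonist activity at histamine H2 receptor (Cavia porcellus), with a stated time of 30 min, in the presence of a further agent that is not named here; on this read-out higher numbers stand for larger maximal responses and lower numbers for smaller maximal responses.
Compound 2 `Cc1nc(N)sc1CCCN/C(N)=N/C(=O)NC(C)c1ccccc1F` gives 0.93 in this assay.
Compound 3 `Cc1nc(N)sc1CCCN/C(N)=N/C(=O)NC(C)c1ccc(Cl)cc1` gives 0.93 in this assay.

Compound 3 stands level with compound 2 at the digits shown, and the two together are the highest of the three numbers, while compound 1 sits clearly lower than both. Among the compounds with values here, the one step between measured neighbours, no change at the digits printed from compound 2 to compound 3 (within the scatter), swapped one whole aromatic ring for another without moving the maximal response beyond the scatter.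

Compound 4 `Cc1ccc(C(C)NC(=O)/N=C(\N)NCCCc2sc(N)nc2C)cc1` differs from compound 3 in a single place: methyl in place of chloro on an aromatic carbon. Within the data shown here, no measured step swaps chloro for methyl; the closest guide is the step from compound 2 to compound 3, a larger change at the same part of the molecule that left the read-out unchanged. Because of no change at the digits printed from compound 2 to compound 3 (within the scatter), a step of no size beyond the scatter is expected in this assay, with a number 0.030 lower from compound 3 to compound 4 (within the scatter) as the expected step. For compound 4 the estimate is 0.9, expected to fall between 0.75 and 1.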

Compound 4, intrinsic activity: the largest response reached, as a fraction of the reference agonist's: 0.85
Compound 4: middle estimate off by 0.050, on the high side, and the stated range covers the measured number.
By their numbers in this assay, from the lowest: compound 1; then compounds 4, 2 and 3 (each within the scatter of the next).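

In this assay, methyl in place of chloro on this aromatic carbon, para to a large group, gives a number 0.080 lower from compound 3 to compound 4 (within the scatter) and so leaves the maximal response within the scatter. The comparison with the 2-fluorophenyl compound gives a number 0.080 lower from compound 2 to compound 4 (within the scatter) as well, so 2-fluorophenyl, 4-chlorophenyl and 4-methylphenyl all sit within the scatter of one another on this saturated chain carbon, and a carbon group here matches the two halogen-bearing rings on this read-out. Nothing available explains why the maximal response holds across these groups.

Still open, on these data alone, is whether the response would hold with an amine, a hydroxyl or a carboxylic acid at this aromatic carbon. A longer group such as butyl or methoxy in the same place would show how far this freedom extends.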